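The compounds below may be only part of what the source reports. "The series", "measured", "known", "first", "only" and "open" are said of these compounds alone.

Measured compounds:

Compound 1: `COc1nc2c(c(=O)n(C)c(=O)n2C)n1CCCC(=O)Nc1cccc(Cl)c1`. In an assay on isolated protein for inhibition of high affinity 3',5'-cyclic-AMP phosphodiesterase 7A (Homo sapiens), read by cAMP accumulation, with a stated time of 10 min (on this read-out lower numbers stand for stronger inhibition and higher numbers for weaker inhibition), compound 1 gives > 200000 nM, which is a limit of the assay and not a number.
Compound 2: `COc1nc2c(c(=O)n(C)c(=O)n2C)n1CCCC(=O)Nc1ccc(Cl)cc1`. In this assay compound 2 gives > 200000 nM, again a limit.
Compound 3: `CCOc1nc2c(c(=O)n(C)c(=O)n2C)n1CC(=O)Nc1cccc(Cl)c1`. In this assay compound 3 gives > 200000 nM, also a limit.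

All three results sit at the same point, namely (the limit of > 200000 nM in this assay, at which 3 of the 3 values shown sit), so none of the three compounds shows measurable inhibition here. Compound 1 and compound 2 differ by 4-chlorophenyl in place of 3-chlorophenyl on an amide-type nitrogen. The step this change made, a step that the two limits leave unreadable from compound 1 to compound 2, cannot be read because both values rest at the limit of > 200000 nM in this assay, at which 3 of the 3 values shown sit. How the core of compound 1 and the core of compound 3 differ is not broken down here; the two differ in more than one place.

Compound 4, `CCOc1nc2c(c(=O)n(C)c(=O)n2C)n1CC(=O)Nc1ccc(Cl)cc1`, has not yet been measured. It differs from compound 3 by 4-chlorophenyl in place of 3-chlorophenyl on an amide-type nitrogen, and the place is the same word for word as in the change from compound 1 to compound 2, so it is the same change. The earlier step gave no readable size. Given that compound 3 stands at a limit with > 200000 nM, and that the same change from compound 1 to compound 2 left both values at a limit, the expectation is that compound 4 will also stand at a limit, so the expected step from compound 3 to compound 4 is a number no higher from compound 3 to compound 4 (the limit leaves the size open). For compound 4 the estimated value is therefore 200000 nM, with an expected range from 100000 nM to 400000 nM.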

Compound 4, half-maximal inhibitory concentration: > 200000 nM
Compound 4: a limit, no number (the forecaster's own chance of this, stated with the estimate: 90%); the middle value lies on the limit itself.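

Compound 4 is also a limit and not a number, so the step from compound 3 to compound 4, like the one from compound 1 to compound 2, cannot be read: the values stay at one point: the limit of > 200000 nM in this assay, at which 4 of the 4 values shown sit.

What the compounds shown leave open is whether moving the chlorine from 3-chlorophenyl to 4-chlorophenyl changes inhibition at all in this assay.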